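The compounds below may be only part of what the source reports. "The series", "measured", "known", "first", "only" and "open" are said of these compounds alone.

Of the compounds shown here, three of a shared core have been measured in an assay on HEK293 cells for inhibition of Voltage-dependent T-type calcium channel subunit alpha-1G (Homo sapiens), read by fluorescence, tested at 10 uM; on this read-out lower numbers stand for less inhibition and higher numbers for more inhibition at the one concentration tested (going by the name of the read-out). Compound 1, with the structure `CCCc1nc(-c2ccccc2)c(CNCCN2CCN(c3ccccc3F)CC2)o1`, gives 46.5% in this assay. Compound 2, with the structure `CCCc1nc(-c2ccccc2)c(CNCCCN2CCN(c3ccc(F)cc3)CC2)o1`, gives 62.5% in this assay. Compound 3, with the structure `Cc1nc(-c2ccccc2)c(CNCCN2CCN(C(c3ccccc3)c3ccccc3)CC2)o1`, gives 57.3% in this assay.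

On these three numbers compound 2 stands highest. Its nearest neighbour is compound 3, whose value lies within the usual scatter of this kind of measurement, so the two cannot be told apart. Compound 1 lies furthest away, and that gap is beyond the scatter.

The next compound, compound 4, with the structure `CCCc1nc(-c2ccccc2)c(CNCCCN2CCN(c3ccccc3Cl)CC2)o1`, has not yet been measured in this assay. It differs from compound 2 in one place: 2-chlorophenyl in place of 4-fluorophenyl on an amine nitrogen in a ring. Among the measured compounds shown here, no measured pair in this set isolates such a change. For the measured compounds named here, compound 1 and compound 2 differ in more than one place, so there is no measured step to lean on.

Given that, only a modest change is expected, in either direction, and most likely none beyond the scatter; the step from compound 2 to compound 4 in this assay is estimated at a number 6.5 percentage points lower from compound 2 to compound 4 (within the scatter). Compound 4 is therefore expected to give about 56% in this assay, within a range from 36% to 76%.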

Compound 4, a percentage reported as inhibition, at one concentration (the size of the read-out at that concentration, not a potency): 64.7%
For compound 4 the middle estimate is 8.7 percentage points below the measured one, and the stated range covers the measured number.
By their numbers in this assay, from the lowest: compound 1; then compounds 3, 2 and 4 (each within the scatter of the next).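

In this assay, among the compounds shown here, putting 2-chlorophenyl in place of 4-fluorophenyl on an amine nitrogen in a ring gives a number 2.2 percentage points higher from compound 2 to compound 4 (within the scatter), the first step in this set that isolates a single change. At this place on the six-membered non-aromatic ring with 2 nitrogen, the two groups therefore cannot be told apart by this read-out, even though they carry different halogens at different places on the phenyl ring. No measurement is available that could explain this match.

This single step changes the halogen and its place together, so it cannot show what either change does alone, and two opposing effects cannot be distinguished from no effect at all. A 4-chlorophenyl group would help to separate the two changes, while a plain phenyl, a 2-methoxyphenyl or a pyridine ring at the same place would show whether this read-out responds to a wider range of groups there.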